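This account rests on a few compounds, and the source may have more. Where it says the series, first, only, none or still open, it means among the compounds named here.

In an ADME assay on Chem1 cells (Homo sapiens) for cytotoxicity (on this read-out lower numbers stand for higher toxicity in this test and higher numbers for lower toxicity in this test), compound 2 (`NCCCCN(C[C@@H]1CN(C(=O)OCc2ccccc2)CCN1)[C@H]1CCCc2cccnc21`) gives > 10 uM, which is a limit of the assay and not a number. Compound 1 (`NCCCCN(C[C@H]1CN(C(=O)OCc2ccccc2)CCN1)[C@H]1CCCc2cccnc21`) gives > 10 uM, again a limit. Compound 3 (`NCCCCN(C[C@H]1CN(S(=O)(=O)c2cc3ccccc3s2)CCN1)[C@H]1CCCc2cccnc21`) gives > 10 uM, also a limit. Compound 2 therefore has no exact position on the scale.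

Compound 4 (`NCCCCN(C[C@@H]1CNCCN1)[C@H]1CCCc2cccnc21`) has hydrogen in place of benzyloxycarbonyl on an amine nitrogen in a ring. Among the compounds with values here, the only measured step is a step that the two limits leave unreadable from compound 1 to compound 2. It offers no size to carry over, and it concerns (the fact that compounds 1 and 2 differ only in the configuration as drawn), not the loss of this group.

Compound 2 shares the limit of > 10 uM in this assay, at which 3 of the 3 values shown sit, with compound 1 and compound 3, so no step beyond the scatter is expected in this assay, in either direction. The expected change is a step that the limit leaves unreadable from compound 2 to compound 4. For compound 4 the estimated value is 20 uM, with an expected range from 10 uM to 100 uM.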

Compound 4, half-maximal toxic concentration: > 10 uM
Compound 4: no number, only a limit; the forecaster's own chance of this, stated with the estimate: 85%; the middle value lies beyond the limit too.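

In this assay compound 4, like compound 2, gives a limit and not a number, so no step can be read between compound 2 and compound 4: the limit of > 10 uM in this assay, at which 4 of the 4 values shown sit. The compounds shown leave open whether hydrogen in place of benzyloxycarbonyl changes toxicity in this test at all.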